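This account rests on a few compounds, and the source may have more. Where it says the series, first, only, none or still open, it means among the compounds named here.

In a functional assay on GC-1 cells (Mus musculus) for cytotoxicity, read by MTT assay, with a stated time of 72 h (on this read-out higher numbers stand for weaker inhibition and lower numbers for stronger inhibition), compound 1 (`Nc1nc(Nc2ccccc2)sc1C(=O)c1cccnc1`) gives 5900 nM, while compound 2 (`Nc1nc(Nc2ccc(S(N)(=O)=O)cc2)sc1C(=O)c1cccnc1`) gives 20000 nM, the higher of the two numbers. Within the data shown here, the only measured step, a 3.4-fold higher number from compound 1 to compound 2 (0.53 log units; beyond the scatter), is modest and lies elsewhere in the molecule, so it bears only indirectly on what follows. Compound 3 (`Nc1nc(Nc2ccc(S(N)(=O)=O)cc2)sc1C(=O)c1cccc([N+](=O)[O-])c1`) differs from compound 2 by 3-nitrophenyl in place of pyridin-3-yl on a carbonyl carbon, with 3-nitrophenyl in place of pyridin-3-yl on a carbonyl carbon. Among the measured compounds shown here, with compound 2 at 20000 nM, the higher of the two numbers so far, a modest move towards a lower number is expected in this assay. The expected step is a 1.7-fold lower number from compound 2 to compound 3 (0.22 log units; within the scatter). For compound 3 the estimated value is 12000 nM, within an expected range of 4000 nM to 35000 nM.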

Compound 3, half-maximal inhibitory concentration: 22000 nM
Beside the measured number, compound 3's estimate is 1.8-fold (0.26 log units) below it; low and high end bracket the measured number.
By their numbers in this assay, from the lowest: compound 1; then compounds 2 and 3 (each within the scatter of the next).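

In this assay, among these compounds, the first change at the carbonyl carbon, 3-nitrophenyl in place of pyridin-3-yl, gives a 1.1-fold higher number from compound 2 to compound 3 (0.04 log units; within the scatter) and so does not separate compound 2 from compound 3. Among the compounds shown here, the earlier step lay elsewhere in the molecule, so this is the first sign that, with the sulfamoyl group present, this exchange of rings makes no difference beyond the scatter. No evidence is available to explain this result. From the compounds shown here alone, whether an amine or a carboxylic acid in place of the nitro group would separate from compound 2 remains open. So does whether the same exchange would read alike on compound 1, which lacks the sulfamoyl group.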